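A few compounds are considered here, and "the series" means these few. Any claim that something is new, unique, unknown or untested is made for them only; others in the source may bear on it.

Measured so far:
- compound 1 `CCOC(=O)C1=CCCCC1S(=O)(=O)Nc1ccc(F)cc1`: 110 nM
- compound 2 `CCOC(=O)C1=CCCCC1S(=O)(=O)Nc1ccc(F)cc1F`: 16 nM
- compound 3 `CCOC(=O)C1=CCCCC1S(=O)(=O)Nc1ccccc1CC`: 130 nM

In a functional assay on RAW264.7 cells (Mus musculus) for inhibition (on this read-out lower numbers stand for stronger inhibition and higher numbers for weaker inhibition), compound 1 lies within the scatter of compound 3, while compound 2 lies clearly lower. Next is compound 4 `CCOC(=O)C1=CCCCC1S(=O)(=O)Nc1nncs1`, with 1,3,4-thiadiazol-2-yl in place of 4-fluorophenyl on a sulfonamide nitrogen. Going by the values given here, the only measured step, a 6.9-fold lower number from compound 1 to compound 2 (0.84 log units; beyond the scatter), is modest and comes from fluoro in place of hydrogen on an aromatic carbon. Among the compounds with values here, it shows that this group can move the number, but no measured compound replaces the six-membered ring. A larger move than that step is therefore expected, towards weaker inhibition, and this direction remains uncertain. The expected step is an 8.2-fold higher number from compound 1 to compound 4 (0.91 log units; beyond the scatter). For compound 4 the estimated value is 900 nM, with an expected range of 150 nM to 5000 nM.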

Compound 4, half-maximal inhibitory concentration: > 10000 nM
Compound 4 gave a limit, no number; the forecaster's own chance of this, stated with the estimate: 15%; middle value at least 11-fold (1.04 log units) from the limit.
By their numbers in this assay, from the lowest: compound 2; then compounds 1 and 3 (each within the scatter of the next). At a limit, above all of these: compound 4.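

In this assay, replacing the whole ring on the sulfonamide nitrogen gives an at least 90-fold higher number from compound 1 to compound 4 (1.95 log units; beyond the scatter), a larger change than the fluoro step, a 6.9-fold lower number from compound 1 to compound 2 (0.84 log units; beyond the scatter). Compound 4 gives a limit, not a number: the limit of > 10000 nM in this assay, at which 1 of the 4 values shown sits. Among the compounds shown, measurable inhibition occurs only with a six-membered aromatic ring of carbon only at this position, so this position tolerates far less than the substitution on that ring suggested.

As far as these compounds go, compound 4 changes ring size and hetero atoms together, so the contribution of each remains open. A pyridin-2-yl or a cyclohexyl group on the sulfonamide nitrogen would help separate them.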